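Methoxy addition on two cores of one thioether nucleoside series

The compounds below may be only part of what the source reports. "The series", "measured", "known", "first", "only" and "open" are said of these compounds alone.

Working notes. Compound 1 `O=c1oc2ccccc2cc1CSc1nc2cncnc2n1[C@@H]1O[C@H](CO)[C@@H](O)[C@H]1O` and compound 2 `COc1cccc2cc(CSc3nc4cncnc4n3[C@@H]3O[C@H](CO)[C@@H](O)[C@H]3O)c(=O)oc12` share one core; compound 3 `CC1(C)O[C@@H]2[C@H](O1)[C@H](n1c(SCc3cc4ccccc4oc3=O)nc3cncnc31)O[C@@H]2CO` carries a different core, and the difference between the two cores is not broken down here. In a functional assay on Huh-5-2 cells (Homo sapiens) for cytotoxicity, read by microscopy (a lower number here means that less compound is tolerated, a higher number that more compound is tolerated), compound 1 gives 50000 nM, compound 2 gives 47000 nM and compound 3 gives 8800 nM. Compound 3 thus stands lowest of the three, and its gaps to compound 1 and to compound 2 lie beyond the scatter, whereas the gap between compound 1 and compound 2 lies within it.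

The change from compound 1 to compound 2 is methoxy in place of hydrogen on an aromatic carbon and made a 1.1-fold lower number from compound 1 to compound 2 (0.03 log units; within the scatter). Compound 4 `COc1cccc2cc(CSc3nc4cncnc4n3[C@@H]3O[C@H](CO)[C@@H]4OC(C)(C)O[C@@H]43)c(=O)oc12` is not yet measured; it differs from compound 3 by methoxy in place of hydrogen on an aromatic carbon, the same change, now applied to the core of compound 3.

Because the earlier step of a 1.1-fold lower number from compound 1 to compound 2 (0.03 log units; within the scatter) stayed within the scatter, the step from compound 3 to compound 4 is expected to be small as well, about a 1.0-fold lower number from compound 3 to compound 4 (0.02 log units; within the scatter). For compound 4 in this assay the estimate is 8500 nM, expected to fall between 4000 nM and 18000 nM. Going by these compounds, whether the second core alters this picture remains open until the measurement is in.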

Compound 4, half-maximal cytotoxic concentration: 8400 nM
For compound 4 the middle estimate is 1.0-fold (0.01 log units) above the measured one; the range from low to high includes it.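

In this assay the methoxy change carries over from the core of compound 1 to the core of compound 3 with no visible effect on either, a 1.0-fold lower number from compound 3 to compound 4 (0.02 log units; within the scatter) being the new step, and the two steps agree: the same change on two cores in this assay, a 1.1-fold lower number (0.03 log units; within the scatter) from compound 1 to compound 2 and a 1.0-fold lower number (0.02 log units; within the scatter) from compound 3 to compound 4, 1.0-fold (0.01 log units) apart, within the scatter of two such steps. The gap between the cores persists with methoxy in place, with a 5.6-fold lower number from compound 2 to compound 4 (0.75 log units; beyond the scatter), which matches what the values without methoxy show, where compound 1 gives 50000 nM and compound 3 gives 8800 nM. These two steps show only that this one methoxy placement gives no step beyond the scatter on these two cores; they do not show that a step of visible size would carry over in the same way.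

Still open, going by these compounds, is how other groups on this aromatic carbon, such as an amine or a carboxylic acid, would behave on the two cores. Also open, on these data alone, is which part of the difference between the two cores carries the gap.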